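Pyroglutamyl dipeptide prolinamides: side chain at the central carbon

A few compounds are considered here, and "the series" means these few. Any claim that something is new, unique, unknown or untested is made for them only; others in the source may bear on it.

Measured compounds:
compound 1, `CSCC[C@@H](NC(=O)[C@H]1CCC(=O)N1)C(=O)N1CCC[C@@H]1C(N)=O`, 40%
compound 2, `NC(=O)[C@H]1CCCN1C(=O)CNC(=O)[C@H]1CCC(=O)N1`, 10%
compound 3, `NC(=O)[C@H]1CCCN1C(=O)[C@H](CC1CCCCC1)NC(=O)[C@H]1CCC(=O)N1`, 20%

The three compounds share one core and differ only in the group on a saturated chain carbon bound to an amide-type nitrogen and a carbonyl carbon. In a functional assay on the whole organism for inhibition, with Rattus norvegicus as the target, at a dose of 80 mg/kg by the intravenous route (on this read-out lower numbers stand for less inhibition and higher numbers for more inhibition at the one dose given (going by the name of the read-out)), compound 2 carries hydrogen at that carbon and gives the lowest of the three numbers; its nearest neighbour is compound 3, whose value lies within the scatter, and the furthest is compound 1, whose value lies beyond it.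

Compound 4, `CC(C)(C)OC[C@@H](NC(=O)[C@H]1CCC(=O)N1)C(=O)N1CCC[C@@H]1C(N)=O`, is not yet measured. Against compound 2 the change is (tert-butoxy)methyl in place of hydrogen on a saturated chain carbon bound to an amide-type nitrogen and a carbonyl carbon.

Two measured steps start from the same hydrogen at the same place. The step of a number 30 percentage points lower from compound 1 to compound 2 (beyond the scatter) shows a side chain of comparable length going with a modestly higher number, while a number 10 percentage points higher from compound 2 to compound 3 (within the scatter) shows a bulkier side chain going with a change inside the scatter. On this footing compound 4 is expected to lie above compound 2 by a small to modest amount, and the step is estimated as a number 15 percentage points higher from compound 2 to compound 4 (beyond the scatter). The value of compound 4 in this assay is therefore estimated at 25%, with a range from 10% to 45%.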

Compound 4, a percentage reported as inhibition, in the whole organism at one dose (the size of the read-out at that dose, not a potency): 0%
For compound 4 the middle estimate is 25 percentage points above the measured one, outside the stated range (below it).
By their numbers in this assay, from the lowest: compounds 4, 2 and 3 (each within the scatter of the next, the first and the last beyond it); then compound 1.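

In this assay, (tert-butoxy)methyl in place of hydrogen gives a number 10 percentage points lower from compound 2 to compound 4 (within the scatter), so adding this ether side chain at this carbon does not separate compound 4 from the hydrogen compound. The change of tert-butoxy in place of (methylsulfanyl)methyl, two bonds along the chain from an amide-type nitrogen and a carbonyl carbon, gives a number 40 percentage points lower from compound 1 to compound 4 (beyond the scatter), which shows that the read-out depends on what the side chain carries and not simply on a side chain being present: among the side chains compared with hydrogen, only the 2-(methylsulfanyl)ethyl of compound 1 stands clear of it, while cyclohexylmethyl and (tert-butoxy)methyl do not. No supporting data bear on why these side chains differ.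

The compounds shown leave open whether the sulfur atom or the unbranched chain of compound 1 goes with its higher number, a question that a plain n-butyl or a 2-methoxyethyl side chain at the same carbon would address. They also leave open how a side chain ending in an amine or a carboxylic acid would read at this position.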